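Configuration at one ring carbon in the cyclohexylmethyl compound

The compounds below may be only part of what the source reports. "The series", "measured", "known", "first", "only" and "open" are said of these compounds alone.

In a functional assay on HeLa cells (Homo sapiens) for antiproliferative activity, read by sulforhodamine B assay (a lower number here means a stronger inhibitor of growth, a higher number a weaker inhibitor of growth), compound 1 `O[C@H]1CO[C@H](COCc2ccccc2)[C@@H](OCc2ccccc2)[C@@H]1OCc1ccccc1` reads only as a limit, > 50000 nM. Compound 2 `CC[C@H]1O[C@H](COCc2ccccc2)[C@@H](OCc2ccccc2)[C@H](OCc2ccccc2)[C@H]1O` also reads only as a limit, > 50000 nM. Among the measured compounds shown here, compound 3 `O[C@@H]1[C@@H](OCc2ccccc2)[C@H](OCc2ccccc2)[C@@H](COCc2ccccc2)O[C@H]1CC1CCCCC1` gives 9500 nM, the only true number so far. Ethyl in place of hydrogen on a saturated ring carbon gives a step that the two limits leave unreadable from compound 1 to compound 2. Cyclohexylmethyl in place of hydrogen gives an at least 5.2-fold lower number from compound 1 to compound 3 (0.72 log units; beyond the scatter).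

Compound 4 `O[C@@H]1[C@@H](OCc2ccccc2)[C@H](OCc2ccccc2)[C@@H](COCc2ccccc2)O[C@@H]1CC1CCCCC1` keeps the same atoms and bonds: the two compounds have the same atoms and bonds and differ only in configuration as drawn: 1 of 5 stereo elements differ; a stereocentre at a saturated ring carbon is drawn S in compound 3 and R in compound 4. For the measured compounds named here, no measured step isolates a change of configuration, so the expectation rests on compound 3 at 9500 nM alone. The expected step in this assay is a 2.1-fold higher number from compound 3 to compound 4 (0.32 log units; beyond the scatter), towards weaker growth inhibition. Compound 4 is estimated at 20000 nM, with an expected range of 7000 nM to 50000 nM.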

Compound 4, concentration for 50% growth inhibition: > 50000 nM
Compound 4: only a limit was reported; the forecaster's own chance of this, stated with the estimate: 30%; at least 2.5-fold (0.39 log units) between middle value and limit.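

In this assay, an at least 5.2-fold higher number from compound 3 to compound 4 (0.72 log units; beyond the scatter), so the cyclohexylmethyl group gives a readable number only with the centre drawn S, as in compound 3. The step can be put down to this one centre alone because of a single fact: the fact that compounds 3 and 4 differ only in the configuration as drawn. The steps among compound 1, compound 2 and compound 4 cannot be read, and the reason is: the limit of > 50000 nM in this assay, at which 3 of the 4 values shown sit.

Going by these compounds, compound 4 reads only as a limit, so the full size of the step stays open. On these data alone, whether a longer alkyl chain or an amine at this carbon would show the same dependence on configuration also stays open.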